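The compounds below may be only part of what the source reports. "The series", "measured", "known", "first", "only" and "open" are said of these compounds alone.

Compound 1 `CC(C)C[C@]1(O)NC(=O)[C@]2(OC(Cc3ccccc3)=CC2=O)[C@H]1O` was examined in an ADME assay on HEK293 cells (Homo sapiens) for cytotoxicity, read by WST assay, with a stated time of 48 h; on this read-out higher numbers stand for weaker inhibition and lower numbers for stronger inhibition. In this assay compound 1 gives > 50000 nM, which is a limit of the assay and not a measured number. Compound 2 `CC(C)CC(=O)C1Oc2cc(Cc3ccccc3)[nH]c(=O)c2O1` was examined in the same way. In this assay compound 2 gives > 50000 nM, again a limit rather than a number. Compound 3 `CC1=CC(=O)[C@@]2(O[C@H]2C(=O)CC(C)C)C(=O)N1` was also entered in this assay, and there compound 3 gives "not determined" (no result reported), so no result is available for it. On the numbers shown, compound 1 therefore stands at the limit of > 50000 nM in this assay, at which 2 of the 3 values shown sit, and nothing in the set points to a stronger or weaker effect on the cells.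

Compound 4 `CC1=CC(=O)[C@]2(O1)C(=O)N[C@@](O)(CC(C)C)[C@@H]2O` differs from compound 1 in a single place: hydrogen in place of phenyl on a saturated chain carbon bound to a double-bonded ring carbon. Among the measured compounds shown here, no step between two measured compounds is available to say how this kind of change shifts the read-out, so the expectation rests only on where compound 1 and compound 2 stand. The step of a number no higher from compound 1 to compound 4 (the limit leaves the size open) is expected to be none beyond the usual scatter, with a good chance that the assay again reports only a limit. Compound 4 is accordingly expected to give 50000 nM, within a range from 25000 nM to 100000 nM.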

Compound 4, half-maximal inhibitory concentration: > 50000 nM
Compound 4: no number, only a limit; the forecaster's own chance of this, stated with the estimate: 80%; the middle value lies on the limit itself.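

Compound 1 and compound 4 both give only a limit of this assay and not a number, so no step can be read between them. The compounds shown leave open how strongly any of them acts on the cells, and whether hydrogen in place of phenyl changes that at all: the limit of > 50000 nM in this assay, at which 3 of the 4 values shown sit.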